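The compounds below may be only part of what the source reports. "The series", "measured", "known", "first", "only" and "open" are said of these compounds alone.

Compound 2 `O=c1c2ccccc2c(-c2cccnc2)nn1Cc1ccccc1` gives the lowest number of the three in a functional assay (trachea) with Cavia porcellus as the target (a lower number here means a stronger inhibitor, a higher number a weaker inhibitor), with 2450 nM. Compound 3 `O=c1c2ccccc2c(-c2cccnc2)nn1CCCCSc1ncccn1` stands nearest to it, and in this assay compound 3 gives 6170 nM, a gap beyond the scatter. Compound 1 `Oc1nnc(-c2cccnc2)c2ccccc12` lies furthest off; in this assay compound 1 gives 10200 nM, also beyond the scatter. No two of the measured compounds differ in a single place, so no single step can be read from them. Compound 4 `O=C(O)c1ccc(Cn2nc(-c3cccnc3)c3ccccc3c2=O)cc1` is not yet measured. It differs from compound 2 by carboxy in place of hydrogen on an aromatic carbon. The measured compounds offer no guide to this change; a small weakening, near the edge of the scatter, is expected, a 1.4-fold higher number from compound 2 to compound 4 (0.15 log units; within the scatter). Compound 4 is estimated at 3500 nM in this assay, with a range from 1000 nM to 12000 nM.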

Compound 4, half-maximal inhibitory concentration: 17000 nM
Estimate against measurement, compound 4: 4.9-fold (0.69 log units) below; measured number above the stated range.
By their numbers in this assay, from the lowest: compound 2; then compounds 3, 1 and 4 (each within the scatter of the next, the first and the last beyond it).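

In this assay, the change from phenyl to 4-carboxyphenyl gives a 6.9-fold higher number from compound 2 to compound 4 (0.84 log units; beyond the scatter), the first single-place step available in the series. It shows that carboxy on this aromatic carbon, para to a large group, is not tolerated as a neutral substitution: the change costs activity rather than leaving it unchanged. From the compounds shown here alone, whether a methyl ester, a primary amide or a methyl group at this same place would give a number closer to that of compound 2 remains open. Nothing in the data shown accounts for the loss.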